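A Core Exchange Against a Flat Limit

This account rests on a few compounds, and the source may have more. Where it says the series, first, only, none or still open, it means among the compounds named here.

In a functional assay on HCT-116 cells (Homo sapiens) for antiproliferative activity, read by MTT assay, with a stated time of 68 h (a higher number here means a weaker inhibitor, a lower number a stronger inhibitor), compound 1 (`O=S(=O)(Nc1ccc(F)c(C#Cc2cnc3[nH]ncc3c2)c1F)c1cccc(F)c1`) gives > 10000 nM, which is a limit and not a number. Compound 2 (`O=S(=O)(Nc1ccc(F)c(C#Cc2cnc3[nH]ncc3c2)c1F)c1ccccn1`) gives > 10000 nM, also a limit. Compound 3 (`O=S(=O)(Nc1ccc(F)c(C#Cc2cnc3[nH]ncc3c2)c1F)c1cccnc1`) gives > 10000 nM, again a limit. Compound 3 thus stands with the other two, at the limit of > 10000 nM in this assay, at which 3 of the 3 values shown sit.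

Compound 4 (`O=S(=O)(Nc1ccc(F)c(C#Cc2cnc3[nH]ccc3c2)c1F)c1cccnc1`) differs from compound 3 by one exchange: a group of 9 heavy atoms (7 carbon, 2 nitrogen; one five-membered aromatic ring with 1 hetero atom, one six-membered aromatic ring with 1 hetero atom) in place of a group of 9 heavy atoms (6 carbon, 3 nitrogen; one five-membered aromatic ring with 2 hetero atoms, one six-membered aromatic ring with 1 hetero atom), on a triple-bonded carbon.

The measured steps are a step that the two limits leave unreadable from compound 1 to compound 2, a step that the two limits leave unreadable from compound 1 to compound 3 and a step that the two limits leave unreadable from compound 2 to compound 3. All three change the group on the sulfonyl sulfur, none touches the group exchanged here, and none has a readable size. The expectation therefore rests only on compound 3 with its limit of > 10000 nM. The expected change is an at least 1.2-fold lower number from compound 3 to compound 4 (0.09 log units; that floor lies within the scatter), a small step whose direction is uncertain. Compound 4 is estimated at 8000 nM in this assay. The expected range for compound 4 runs from 2000 nM to 20000 nM.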

Compound 4, half-maximal inhibitory concentration: > 10000 nM
Compound 4 was reported as a limit; the forecaster's own chance of this, stated with the estimate: 65%; middle value at least 1.2-fold (0.09 log units) from the limit.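

In this assay compound 4 gives > 10000 nM, a limit and not a number. Going by these compounds alone, compound 3 also stands at a limit, so no step from compound 3 to compound 4 can be read. The compounds shown leave open whether either exchange, on the sulfonyl sulfur or on the triple-bonded carbon, changes activity at all in this assay.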